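The source may hold more compounds than are shown below. What is called first, only, known or untested is meant among the compounds shown, and "the series" means these compounds.

Of the compounds shown here, three have been measured in an assay on COS-1 cells for displacement of a labelled ligand from sodium-dependent dopamine transporter (Homo sapiens); a higher number here means a weaker inhibitor, a lower number a stronger inhibitor. Compound 1 `COC(=O)C1=C(c2ccc(OC(F)(F)F)cc2)CCC1` gives 2650000 nM in this assay. Compound 2 `COC(=O)C1=C(c2cccc(Cl)c2)CCCC1` gives 22000 nM, and compound 3 `COC(=O)C1=C(c2ccc(C(C)(C)C)cc2)CCCC1` gives 605000 nM. Among the three numbers, compound 3 stands second highest: its nearest neighbour is compound 1, whose number is higher by a margin beyond the scatter, while compound 2 lies furthest away with a number lower by a margin well beyond the scatter. Compound 2 and compound 3 share the same core and differ only in what sits on the aromatic ring and where.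

Compound 4 `COC(=O)C1=C(c2ccccc2)CCCC1` has not yet been measured in this assay. It differs from compound 3 in one place: hydrogen in place of tert-butyl on an aromatic carbon. Among the compounds with values here, no measured pair here shows this change directly, so its effect can only be guessed from the spread of the three numbers. Compound 3, carrying the tert-butyl group, sits far from compound 2, and removing that group is expected to move the number downward rather than upward, by a step that should exceed the scatter: the step from compound 3 to compound 4 is estimated as a 6.1-fold lower number from compound 3 to compound 4 (0.78 log units; beyond the scatter). Compound 4 is therefore expected to give about 100000 nM in this assay, with a plausible range from 30000 nM to 400000 nM.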

Compound 4, inhibition constant: 630000 nM
Compound 4: middle estimate off by 6.3-fold (0.80 log units), on the low side; measured number outside the range, above it.
By their numbers in this assay, from the lowest: compound 2; then compounds 3 and 4 (each within the scatter of the next); then compound 1.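

In this assay, within the data shown here, hydrogen in place of tert-butyl on an aromatic carbon gives a 1.0-fold higher number from compound 3 to compound 4 (0.02 log units; within the scatter), so at this place the tert-butyl group and hydrogen cannot be told apart, which no earlier pair could show. The other pair on the same core reads quite differently: hydrogen in place of chloro on an aromatic carbon gives a 29-fold higher number from compound 2 to compound 4 (1.46 log units; beyond the scatter), so among these compounds only the chloro group of compound 2 stands apart from the unsubstituted compound 4, while compound 3 does not. Nothing available explains why one group matters here and the other does not.

On these data alone, whether an amine or a carboxylic acid on the aromatic carbon that carries tert-butyl in compound 3 would also match compound 4 stays open, as does whether chloro would keep its large step if it stood on that same carbon. Compound 1, with its trifluoromethoxy group, differs from the others in more than one place, so what that group contributes on its own cannot be read from these compounds.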